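The source may hold more compounds than are shown below. What is called first, only, known or untested is meant among the compounds shown, and "the series" means these compounds.

Measured compounds in a functional assay on CHO cells for agonist activity at Free fatty acid receptor 1 (Homo sapiens), read by a luciferase reporter; on this read-out lower numbers stand for smaller maximal responses and higher numbers for larger maximal responses:
Compound 1 `Cc1nc(-c2ccc(C(F)(F)F)cc2)sc1CNc1ccc(C(=O)O)cc1` — 10%
Compound 2 `Cc1nc(-c2ccc(C(F)(F)F)cc2)sc1CNc1ccc(CCCC(=O)O)cc1` — 44%
Compound 3 `Cc1nc(-c2ccc(C(F)(F)F)cc2)sc1CNc1ccc(/C=C/C(=O)O)cc1` — 95%

Compound 3 stands highest of the three numbers; the steps of a number 85 percentage points higher from compound 1 to compound 3 (beyond the scatter) and a number 51 percentage points higher from compound 2 to compound 3 (beyond the scatter) both lie beyond the scatter. Compound 4 `Cc1nc(-c2ccc(C(F)(F)F)cc2)sc1CNc1ccc(CC(C)C(=O)O)cc1` differs from compound 3 by 2-carboxypropyl in place of 2-carboxyethenyl on an aromatic carbon. The step that bears most is a number 51 percentage points higher from compound 2 to compound 3 (beyond the scatter): the entering 2-carboxypropyl, like 3-carboxypropyl, carries only one double bond outside aromatic rings, so the reverse of that step is expected for compound 4. The step of a number 34 percentage points higher from compound 1 to compound 2 (beyond the scatter) suggests such a chain still stays well above compound 1. A drop beyond the scatter is therefore expected, about a number 45 percentage points lower from compound 3 to compound 4 (beyond the scatter). For compound 4 the estimate in this assay is 50%, with a range from 25% to 80%.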

Compound 4, largest response reached (reported as percent of maximum), in percent of the reference or control that the assay uses: 100%
Compound 4: the middle estimate sits 50 percentage points below what was measured; the measured number lies above the stated range.
By their numbers in this assay, from the lowest: compound 1; then compound 2; then compounds 3 and 4 (each within the scatter of the next).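

In this assay the 2-carboxypropyl group of compound 4 is not separated from the 2-carboxyethenyl group of compound 3 (a number 5 percentage points higher from compound 3 to compound 4 (within the scatter)), so a second double bond outside aromatic rings is not needed for a large maximal response at this place. Among chains with one such double bond, the arrangement of the chain matters (a number 56 percentage points higher from compound 2 to compound 4 (beyond the scatter)), and the gain over the carboxy group is large (a number 90 percentage points higher from compound 1 to compound 4 (beyond the scatter)). Nothing at hand gives a reason for these steps.

Open, on these data alone, is whether a longer branched chain such as 2-carboxybutyl, or a tetrazole in place of the carboxylic acid, keeps this response.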